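Carbamate in place of sulfonamide on a piperidine amide

The compounds below may be only part of what the source reports. "The series", "measured", "known", "first", "only" and "open" are said of these compounds alone.

The study concerns three measured compounds and one that awaits measurement. Compound 1 `CC(C)C(NS(=O)(=O)Cc1ccccc1)C(=O)N1CCC(c2ccc(Cl)cc2)CC1` carries a benzylsulfonyl group on its amine nitrogen; in an assay on THP-1 cells for displacement of a labelled ligand from C-C chemokine receptor type 1 (Homo sapiens) (on this read-out higher numbers stand for weaker inhibition and lower numbers for stronger inhibition), compound 1 gives 303 nM. Compound 2 `CC(C)C(NC(=O)c1ccccc1)C(=O)N1CCC(c2ccc(F)cc2)CC1` gives 423 nM in this assay, and compound 3 `CC(C)C(NC(=O)c1ccccc1)C(=O)N1CCN(c2ccc(Cl)cc2)CC1` gives 525 nM. The figures of compound 2 and compound 3 sit within the usual scatter of that of compound 1, so the three compounds cannot be told apart on this read-out.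

Compound 4 `CC(C)C(NC(=O)Oc1ccccc1)C(=O)N1CCC(c2ccc(Cl)cc2)CC1` differs from compound 1 in one place: phenoxycarbonyl in place of benzylsulfonyl on an amine nitrogen. For the measured compounds named here, no measured pair shows the effect of this exchange directly. Since the benzoyl-bearing compound 2 and compound 3 gave figures close to compound 1, a different carbonyl-linked group on the same nitrogen is expected to leave the number near where it is. The step from compound 1 to compound 4 is therefore estimated as a 1.2-fold higher number from compound 1 to compound 4 (0.06 log units; within the scatter), that is, no change beyond the scatter. Compound 4 is expected to give 350 nM in this assay, within a range from 120 nM to 1000 nM.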

Compound 4, half-maximal inhibitory concentration: 265 nM
Compound 4: middle estimate off by 1.3-fold (0.12 log units), on the high side, and the stated range covers the measured number.
By their numbers in this assay, from the lowest: compounds 4, 1, 2 and 3 (each within the scatter of the next).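

In this assay, phenoxycarbonyl in place of benzylsulfonyl on the amine nitrogen gives a 1.1-fold lower number from compound 1 to compound 4 (0.06 log units; within the scatter), the only direct reading of a change at this position among the compounds shown. For the compounds shown here, with the rest of the core of compound 1 held fixed, a sulfonyl-linked group and a carbamate on this nitrogen therefore cannot be told apart on this read-out, which the earlier compounds could not show because none of them formed a pair differing in one place. Nothing measured on these two groups accounts for this result.

On these data alone, what stays open is whether an aromatic ring is needed on this nitrogen, as a group such as ethoxycarbonyl would tell, and whether an amine or a carboxylic acid on the ring of phenoxycarbonyl would move the number. As far as these compounds go, whether benzyloxycarbonyl, with its longer chain, would keep the number in the same range also stays open.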